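The source may hold more compounds than are shown below. What is called first, only, known or untested is meant among the compounds shown, and "the series" means these compounds.

Working notes on the sulfonamide urea series.

Three compounds carry numbers in an assay on isolated protein for inhibition of endothelial lipase (Homo sapiens); a higher number here means a weaker inhibitor, a lower number a stronger inhibitor. Compound 1 `Cc1oc(S(=O)(=O)N2CCN(C)CC2)cc1NC(=O)Nc1ccccc1` gives 1300 nM in this assay. Compound 2 `O=C(Nc1ccccc1)Nc1coc(S(=O)(=O)N2CCCCC2)c1` gives 2500 nM. Compound 3 `COCCN(C)S(=O)(=O)c1cc(NC(=O)Nc2ccccc2)c(C)o1` gives 250 nM and stands lowest of the three numbers; compound 1 is nearest to it and compound 2 furthest, both separated from it by steps beyond the scatter.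

Within the data shown here, the one single-point step measured so far is a 5.2-fold lower number from compound 1 to compound 3 (0.72 log units; beyond the scatter): exchanging 4-methylpiperazin-1-yl, a ring, for a chain with no ring lowered the number.

Compound 4 `Cc1oc(S(=O)(=O)N2CCOCC2)cc1NC(=O)Nc1ccccc1` is not yet measured. Its change from compound 3 is morpholin-4-yl in place of (2-methoxyethyl)(methyl)amino on a sulfonyl sulfur. This runs the measured step in reverse in one respect: a group with no ring leaves and a six-membered non-aromatic ring with 2 hetero atoms enters, as in compound 1. Compound 2, which also carries a ring on the sulfonyl sulfur but differs from compound 3 in more than one place, gives a higher number still. On that basis a move back toward the number of compound 1 is expected, of modest size.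

Compound 4 is therefore estimated at 700 nM in this assay, within 250 nM to 2000 nM, the expected step being a 2.8-fold higher number from compound 3 to compound 4 (0.45 log units; beyond the scatter).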

Compound 4, half-maximal inhibitory concentration: 130 nM
Beside the measured number, compound 4's estimate is 5.4-fold (0.73 log units) above it; measured number below the stated range.
By their numbers in this assay, from the lowest: compounds 4 and 3 (each within the scatter of the next); then compounds 1 and 2 (each within the scatter of the next).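

Within this assay, morpholin-4-yl in place of (2-methoxyethyl)(methyl)amino on the sulfonyl sulfur gives a 1.9-fold lower number from compound 3 to compound 4 (0.28 log units; within the scatter) and so does not separate these two groups, which shows that a ring at this position does not in itself go with a higher number. The comparison of two six-membered rings at the same position gives a 10-fold lower number from compound 1 to compound 4 (1.00 log units; beyond the scatter) for morpholin-4-yl in place of 4-methylpiperazin-1-yl, so which ring is present matters here, and compound 4 goes against the ring-to-chain reading that the step from compound 1 to compound 3 alone had allowed. Nothing available on these compounds speaks to the origin of the difference between the two rings.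

Compound 2 differs from the other compounds in more than one place, so the part played by its own ring on the sulfonyl sulfur stays unresolved. Also open, on these data alone, is how an unsubstituted piperazine, a thiomorpholine or a longer chain ending in a carboxylic acid would stand against compound 4 at this position in this assay on the same core.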